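The source may hold more compounds than are shown below. What is called first, only, known or untested is meant among the compounds shown, and "the series" means these compounds.

Values in a functional assay on DU-145 cells (Homo sapiens) for inhibition, read by trypan blue exclusion, with a stated time of 96 h (a higher number here means a weaker inhibitor of growth, a lower number a stronger inhibitor of growth), for the two compounds measured so far:

Compound 1 `O=C(/C(=C\c1ccc(OCc2ccccc2)cc1)SCc1ccc(Cl)cc1)c1ccc(Cl)cc1` gives 1000 nM
Compound 2 `COc1ccc(/C=C(/SCc2ccc(Cl)cc2)C(=O)c2ccc(Br)cc2)cc1O` gives 1000 nM

Compound 1 stands level with compound 2 at the digits shown, with no difference beyond the usual scatter of repeat measurements. Compound 3 `O=C(/C(=C\c1ccc(Br)cc1)SCc1ccc(Cl)cc1)c1ccc(Cl)cc1` has not yet been measured. It is compound 1 with bromo in place of benzyloxy on an aromatic carbon, para to a large group bromo in place of benzyloxy on an aromatic carbon and the rest of the structure is unchanged. Among the measured compounds shown here, no two measured compounds differ in one place only, so the data give no measured size for such a swap. The value of compound 1 at 1000 nM is therefore the only starting point. In this assay the expected outcome is an estimated step of a 1.3-fold higher number from compound 1 to compound 3 (0.11 log units; within the scatter) that stays within the scatter, with no firm direction. For compound 3 the estimated value is 1300 nM with an expected range of 400 nM to 4500 nM and only the measurement can settle it.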

Compound 3, concentration for 50% growth inhibition: 1000 nM
Estimate against measurement, compound 3: 1.3-fold (0.11 log units) above; measured number inside the range.
By their numbers in this assay, from the lowest: compounds 1, 2 and 3 (each within the scatter of the next).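

Among the compounds shown here, the first comparison of compounds that differ in one place in this assay shows no change at the digits printed from compound 1 to compound 3 (within the scatter), with bromo in place of benzyloxy on an aromatic carbon, para to a large group. The change is large in structure: benzyloxy has 8 heavy atoms, including one six-membered aromatic ring of carbon only and 1 hydrogen-bond acceptor, while bromo is a single heavy atom with no ring, yet this comparison shows no measurable difference in growth inhibition. Nothing available explains this result.

The compounds shown leave open whether an amine, a carboxylic acid or a longer chain at this position would also match compound 1. They also leave open whether the same swap would give the same result on a different core.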